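Moving a Trifluoromethyl Group on a Sulfonyl Sulfur

The source may hold more compounds than are shown below. What is called first, only, known or untested is meant among the compounds shown, and "the series" means these compounds.

Compound 1, `CC(O)(CSc1ccc(C(F)(F)F)cc1)C(=O)Nc1ccc(S(F)(F)(F)(F)F)cc1`, gives 28800 nM in a functional assay on DU-145 cells (Homo sapiens) for antiproliferative activity, read by propidium iodide staining, with a stated time of 96 h; on this read-out lower numbers stand for stronger inhibition and higher numbers for weaker inhibition.
Compound 2, `CC(O)(CSc1cccc(C(F)(F)F)c1)C(=O)Nc1ccc(S(F)(F)(F)(F)F)cc1`, gives 26200 nM in this assay.
Compound 3, `CC(O)(CS(=O)(=O)c1ccc(C(F)(F)F)cc1)C(=O)Nc1ccc(S(F)(F)(F)(F)F)cc1`, gives 29300 nM in this assay.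

All three measured compounds share the same right-hand part and differ only in how the left-hand aryl group is attached. Compound 1 and compound 2 differ by 3-(trifluoromethyl)phenyl in place of 4-(trifluoromethyl)phenyl on a sulfur, and this change made a 1.1-fold lower number from compound 1 to compound 2 (0.04 log units; within the scatter), so the two values show no real separation. The difference between the cores of compound 1 and compound 3 is not broken down here; their values in this assay also lie close together.

Compound 4, `CC(O)(CS(=O)(=O)c1cccc(C(F)(F)F)c1)C(=O)Nc1ccc(S(F)(F)(F)(F)F)cc1`, has not yet been measured. It differs from compound 3 by 3-(trifluoromethyl)phenyl in place of 4-(trifluoromethyl)phenyl on a sulfonyl sulfur. This is the same kind of change as that from compound 1 to compound 2, but not the same: there the change sat on a sulfur whose other neighbours are a saturated chain carbon, here it sits on a sulfonyl sulfur whose other neighbours are a saturated chain carbon.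

For compound 4 the expected step in this assay is a 1.1-fold lower number from compound 3 to compound 4 (0.04 log units; within the scatter), resting on the earlier 1.1-fold lower number from compound 1 to compound 2 (0.04 log units; within the scatter), which stayed within the scatter. Compound 4 is therefore estimated at 27000 nM, with a range from 14000 nM to 55000 nM.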

Compound 4, half-maximal inhibitory concentration: 31900 nM
Beside the measured number, compound 4's estimate is 1.2-fold (0.07 log units) below it; the range from low to high includes it.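

Placing 3-(trifluoromethyl)phenyl where 4-(trifluoromethyl)phenyl stood on the sulfonyl sulfur produces no real separation in this assay, with a 1.1-fold higher number from compound 3 to compound 4 (0.04 log units; within the scatter). Set beside the same change on the plain sulfur of the other core, the two steps cannot be told apart: the same change on two cores in this assay, a 1.1-fold lower number (0.04 log units; within the scatter) from compound 1 to compound 2 and a 1.1-fold higher number (0.04 log units; within the scatter) from compound 3 to compound 4, 1.2-fold (0.08 log units) apart, within the scatter of two such steps

So on these two cores the change behaves alike, in that neither step stands out from the ordinary spread of repeated measurements. This does not show that a real effect of the change would carry from one core to another, and two cores say nothing about the rest of the series.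

The compounds shown leave open whether any change to this aryl group can produce a step beyond the scatter on either core. Going by these compounds, only trifluoromethyl appears on the ring here, so it also stays open how an amine or a carboxylic acid in its place would behave.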